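The source may hold more compounds than are shown below. What is called first, only, known or untested is meant among the compounds shown, and "the series" means these compounds.

Three compounds sharing one core were tested in a functional assay on MCF7 cells (Homo sapiens) for antiproliferative activity, read by MTT assay, with a stated time of 72 h; on this read-out higher numbers stand for weaker inhibition and lower numbers for stronger inhibition. Compound 1 `COc1ccc(N2CCN(C(=S)SCc3ccc4nc(N)nc(N)c4c3)CC2)cc1` gives 1580 nM. Compound 2 `Cc1ccccc1N1CCN(C(=S)SCc2ccc3nc(N)nc(N)c3c2)CC1` gives 4230 nM. Compound 3 `Nc1nc(N)c2cc(CSC(=S)N3CCN(c4ccc(Cl)cc4)CC3)ccc2n1` gives 4880 nM, the highest of the three numbers; its gap to compound 2 stays within the scatter, whereas a 3.1-fold higher number from compound 1 to compound 3 (0.49 log units; beyond the scatter) lies beyond it. Compound 4 `Nc1nc(N)c2cc(CSC(=S)N3CCN(c4ccc(F)cc4F)CC3)ccc2n1` differs from compound 3 in one place: 2,4-difluorophenyl in place of 4-chlorophenyl on an amine nitrogen in a ring. For the measured compounds named here, two measured steps touch the same ring nitrogen: a 1.2-fold higher number from compound 2 to compound 3 (0.06 log units; within the scatter), which stayed within the scatter, and a 2.7-fold higher number from compound 1 to compound 2 (0.43 log units; beyond the scatter), which was modest. Neither of them involves fluorine, so they give only a rough guide. Because a 1.2-fold higher number from compound 2 to compound 3 (0.06 log units; within the scatter) showed that exchanging one aryl group for another at this position can leave the number essentially unchanged, only a small step is expected here: a 1.2-fold lower number from compound 3 to compound 4 (0.09 log units; within the scatter). Compound 4 is therefore estimated at 4000 nM, with a plausible range from 1500 nM to 10000 nM.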

Compound 4, half-maximal inhibitory concentration: 3670 nM
Compound 4: middle estimate off by 1.1-fold (0.04 log units), on the high side; low and high end bracket the measured number.
By their numbers in this assay, from the lowest: compound 1; then compounds 4, 2 and 3 (each within the scatter of the next).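

In this assay, a fluorine-bearing aryl group on this ring nitrogen gives a 1.3-fold lower number from compound 3 to compound 4 (0.12 log units; within the scatter) and a 1.2-fold lower number from compound 2 to compound 4 (0.06 log units; within the scatter), so compounds 2, 3 and 4 form a group whose differences all stay within the scatter. Replacing the single chlorine of 4-chlorophenyl with the two fluorines of 2,4-difluorophenyl therefore produces no readable change here. The step beyond the scatter is a 2.3-fold higher number from compound 1 to compound 4 (0.37 log units; beyond the scatter), which leaves compound 1, with its 4-methoxyphenyl group, as the only one apart from the other three.

No supporting measurement bears on why compound 1 stands apart. Still open, as far as these compounds go, is whether a second methoxy group, or an amine or carboxylic acid on the aryl ring, would lower the number further or return it to that group.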